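This account rests on a few compounds, and the source may have more. Where it says the series, first, only, none or still open, it means among the compounds named here.

Compound 1, with the structure `C=C1CC[C@@H]2[C@](C)(COC(C)=O)[C@H](OC(C)=O)CC[C@@]2(C)[C@H]1CC(Nc1ccc(S(=O)(=O)Nc2nccc(C)n2)cc1)C1=CCOC1=O`, is one of three compounds sharing the same core that have been measured in a functional assay on TK-10 cells (Homo sapiens) for inhibition, read by sulforhodamine B assay, with a stated time of 48 h; a higher number here means a weaker inhibitor of growth, a lower number a stronger inhibitor of growth; in this assay compound 1 gives 4940 nM. Compound 2 `C=C1CC[C@@H]2[C@](C)(COC(C)=O)[C@H](OC(C)=O)CC[C@@]2(C)[C@H]1CC(Nc1ccc(S(=O)(=O)Nc2nccs2)cc1)C1=CCOC1=O` gives 9450 nM, and compound 3 `C=C1CC[C@@H]2[C@](C)(COC(C)=O)[C@H](OC(C)=O)CC[C@@]2(C)[C@H]1CC(Nc1ccc(S(=O)(=O)Nc2ncccn2)cc1)C1=CCOC1=O` gives 2770 nM. Among these three numbers compound 1 stands second highest, with compound 3 nearest to it and compound 2 furthest away, and both of those gaps lie within the scatter.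

Compound 4 `C=C1CC[C@@H]2[C@](C)(COC(C)=O)[C@H](OC(C)=O)CC[C@@]2(C)[C@H]1CC(Nc1ccc(S(=O)(=O)Nc2cc(C)on2)cc1)C1=CCOC1=O` has not yet been measured. It differs from compound 1 in one place: 5-methyl-1,2-oxazol-3-yl in place of 4-methylpyrimidin-2-yl on a sulfonamide nitrogen.

Going by the values given here, two measured steps bear on this change. Among the compounds with values here, the first is the exchange of the six-membered ring on the sulfonamide nitrogen for a five-membered one, seen as a 1.9-fold higher number from compound 1 to compound 2 (0.28 log units; within the scatter). Within the data shown here, the second is the reverse exchange, a 3.4-fold lower number from compound 2 to compound 3 (0.53 log units; beyond the scatter), which is the only step beyond the scatter. The removal of the methyl alone, a 1.8-fold lower number from compound 1 to compound 3 (0.25 log units; within the scatter), stays within the scatter. Taken together, a five-membered ring on the sulfonamide nitrogen has so far gone with a somewhat higher number, so the step of a 1.3-fold higher number from compound 1 to compound 4 (0.12 log units; within the scatter) is expected to be small and, if anything, toward a higher number. Compound 4 is therefore estimated at 6500 nM, within a range of 2500 nM to 16000 nM.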

Compound 4, concentration for 50% growth inhibition: 3040 nM
For compound 4 the middle estimate is 2.1-fold (0.33 log units) above the measured one; the measured number falls inside the stated range.
By their numbers in this assay, from the lowest: compounds 3, 4, 1 and 2 (each within the scatter of the next, the first and the last beyond it).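

In this assay, the five-membered 5-methyl-1,2-oxazol-3-yl on the sulfonamide nitrogen stays within the scatter of both six-membered rings: of 4-methylpyrimidin-2-yl (a 1.6-fold lower number from compound 1 to compound 4 (0.21 log units; within the scatter)) and of pyrimidin-2-yl (a 1.1-fold higher number from compound 3 to compound 4 (0.04 log units; within the scatter)). A five-membered ring at this place therefore does not by itself go with a higher number, a link that rested on compound 2 alone. The exchange of one five-membered ring for another, 5-methyl-1,2-oxazol-3-yl in place of 1,3-thiazol-2-yl, instead gives a step beyond the scatter (a 3.1-fold lower number from compound 2 to compound 4 (0.49 log units; beyond the scatter)), so among these compounds the identity of the ring counts for more than its size, and compound 2 goes against any rule based on ring size.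

The compounds shown leave open what the methyl contributes on the five-membered ring, since the 1,2-oxazol-3-yl without it does not appear among them, and how a pyridin-2-yl or a plain phenyl on the same nitrogen would compare. Nothing available here accounts for why the 1,3-thiazol-2-yl compound stands apart from compounds 3 and 4.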